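Trimming a propyl to methyl on the shared core

The source may hold more compounds than are shown below. What is called first, only, known or untested is meant among the compounds shown, and "the series" means these compounds.

Of the compounds shown here, three have been measured in an assay for inhibition of Rho-associated protein kinase 1 (Homo sapiens), read by TR-FRET, with stated times of 5 min and 2 h; on this read-out higher numbers stand for weaker inhibition and lower numbers for stronger inhibition. Compound 1, `Cc1n[nH]cc1-c1cc2c(s1)C(=O)NC(C)(C)N2C`, gives 54 nM. Compound 2, `CCCC1(C)NC(=O)c2sc(-c3ccncc3)cc2N1`, gives 33 nM; this number sits within the usual scatter of compound 1 and far below compound 3, `Cc1n[nH]cc1-c1cc2c(s1)C(=O)N[C@]1(CC[C@](O)(c3ccc(F)cc3)CC1)N2`, which gives 820 nM. Compound 4, `CC1(C)NC(=O)c2sc(-c3ccncc3)cc2N1`, has not yet been measured. It differs from compound 2 in one place: hydrogen in place of ethyl on a saturated chain carbon bound to a saturated ring carbon. For the measured compounds named here, no pair of measured compounds differs in only this way, so nothing measured speaks directly to the step. A change of this size on a saturated ring carbon is expected to move the number little, and the step of a 1.4-fold higher number from compound 2 to compound 4 (0.13 log units; within the scatter) is estimated to stay within the scatter, leaning slightly toward a weaker result. Compound 4 is expected to give about 45 nM, somewhere between 15 nM and 150 nM.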

Compound 4, half-maximal inhibitory concentration: 90 nM
Estimate against measurement, compound 4: 2.0-fold (0.30 log units) below; the measured number falls inside the stated range.
By their numbers in this assay, from the lowest: compounds 2, 1 and 4 (each within the scatter of the next, the first and the last beyond it); then compound 3.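

At this place, on a saturated chain carbon bound to a saturated ring carbon, the chain does matter in this assay: trimming propyl to methyl gives a 2.7-fold higher number from compound 2 to compound 4 (0.44 log units; beyond the scatter) as a modest but real loss. For the compounds shown here, this is the first reading of any single change in this set, since no earlier pair differed in only one place. Nothing available here accounts for the loss.

Still open, from the compounds shown here alone, is how a butyl chain, or a chain ending in an amine, would read at this same place, and so whether lengthening past propyl helps at all.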